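Trichlorophenyl swap on compound 1: expected loss of activity

A few compounds are considered here, and "the series" means these few. Any claim that something is new, unique, unknown or untested is made for them only; others in the source may bear on it.

In a functional assay on A549 cells (Homo sapiens) for antiproliferative activity, read by MTT assay, with a stated time of 72 h (on this read-out lower numbers stand for stronger inhibition and higher numbers for weaker inhibition), compound 1 `NC1=NC2(CCOCC2)N(OCCCOc2ccc(Cl)cc2)C(N)=N1` gives 360 nM, the lowest of the numeric values, and the nearest, compound 2 `NC1=NC2(CCSCC2)N(OCCCOc2ccc(Br)cc2)C(N)=N1`, gives 740 nM, just beyond the scatter. Compound 3 `NC1=NC2(CCSCC2)N(OCCCOc2cc(Cl)c(Cl)cc2Cl)C(N)=N1` gives > 100000 nM, which is a limit of the assay.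

Compound 4 `NC1=NC2(CCOCC2)N(OCCCOc2cc(Cl)c(Cl)cc2Cl)C(N)=N1` differs from compound 1 by 2,4,5-trichlorophenyl in place of 4-chlorophenyl on an oxygen on a saturated carbon. Within the data shown here, the one measured step bearing on this change is an at least 130-fold higher number from compound 2 to compound 3 (2.13 log units; beyond the scatter), a large step that brings in the same 2,4,5-trichlorophenyl, though on a different core and in place of 4-bromophenyl. A large step towards a higher number, meaning weaker inhibition, is therefore expected in this assay. The expected step is a 110-fold higher number from compound 1 to compound 4 (2.05 log units; beyond the scatter). For compound 4 the estimate is 40000 nM, with an expected range of 4000 nM to 100000 nM.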

Compound 4, half-maximal inhibitory concentration: 680 nM
For compound 4 the middle estimate is 59-fold (1.77 log units) above the measured one; measured number outside the range, below it.
By their numbers in this assay, from the lowest: compounds 1, 4 and 2 (each within the scatter of the next, the first and the last beyond it). At a limit, above all of these: compound 3.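

On the core of compound 1, 2,4,5-trichlorophenyl can replace 4-chlorophenyl with no loss beyond the scatter in this assay: the change gives a 1.9-fold higher number from compound 1 to compound 4 (0.28 log units; within the scatter). Compound 3, which carries the same group on a different core, stays at a limit of > 100000 nM. The large step seen earlier therefore does not follow from the trichlorophenyl group alone.

Whether the core accounts for this contrast remains open. Also open, from the compounds shown here alone, is how an amine or a carboxylic acid on the phenyl ring, or a longer chain, would fare at this position.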